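A pyrazole in place of the benzimidazole

A few compounds are considered here, and "the series" means these few. Any claim that something is new, unique, unknown or untested is made for them only; others in the source may bear on it.

The shared core, carrying a methylpyridinyloxy benzamide, is seen in compound 1 `Cc1cc(C)c(-c2cn(C)cn2)cc1NC(=O)c1ccc(OCc2ccccn2)cc1` and compound 2 `Cc1cc(C)c(-c2nc3ccccc3[nH]2)cc1NC(=O)c1ccc(OCc2ccccn2)cc1`. In a physicochemical assay for lipophilicity (on this read-out higher numbers stand for higher lipophilicity and lower numbers for lower lipophilicity), compound 1 gives 3. For compound 2 this assay gives only a limit, > 3.5, so its exact position is not known. Among the measured compounds shown here, the one measured step, a number at least 0.50 log units higher from compound 1 to compound 2 (beyond the scatter), is accordingly only a lower bound on the rise, as the limit of > 3.5 in this assay, at which 1 of the 2 values shown sits, makes clear.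

Compound 3 `Cc1cc(C)c(-c2c[nH]nc2C)cc1NC(=O)c1ccc(OCc2ccccn2)cc1` changes the same position again: 3-methyl-1H-pyrazol-4-yl in place of 1H-benzimidazol-2-yl on an aromatic carbon. The group that enters is, like the group in compound 1, a single five-membered aromatic ring with 2 hetero atoms, whereas the group that leaves in compound 2 also carries a six-membered aromatic ring of carbon only. Since the step from compound 1 to compound 2 rose by at least a modest amount when that larger group came in, the reverse direction is expected here, a fall of roughly a number at least 0.50 log units lower from compound 2 to compound 3 (beyond the scatter). Compound 3 is therefore estimated at 3, between 2.5 and 3.5.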

Compound 3, distribution coefficient: > 3
Compound 3: no number, only a limit (the forecaster's own chance of this, stated with the estimate: 15%); the middle value sits exactly at the limit.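

In this assay, compound 3 gives only a limit, > 3, and not a number. Putting 3-methyl-1H-pyrazol-4-yl on this aromatic carbon in place of 1-methyl-1H-imidazol-4-yl gives a number no lower from compound 1 to compound 3 (the limit leaves the size open), so this position has now taken a second single five-membered aromatic ring without any fall on this read-out, although the size of the change stays open because the new value is a limit: the limit of > 3 in this assay, at which 1 of the 3 values shown sits. The comparison with 1H-benzimidazol-2-yl, which has the extra six-membered aromatic ring of carbon only, cannot be read, so the loss of that ring cannot be tied to any rise or fall here, because compound 2 also gives only a limit: the limit of > 3.5 in this assay, at which 1 of the 3 values shown sits.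

On these data alone, how far the read-out of compound 3 lies from that of compound 1 or compound 2 remains unknown, as does the part played by the methyl group on the 3-methyl-1H-pyrazol-4-yl ring. The compounds shown also leave open what this assay would give with a group of a different kind at this position, such as a carboxylic acid or an amine.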